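Cyclic sulfonyl urea series: chloro moved to the other benzyl

The compounds below may be only part of what the source reports. "The series", "measured", "known", "first", "only" and "open" are said of these compounds alone.

Compound 2 `O=C1c2ccccc2N(Cc2ccccc2)S(=O)(=O)N1Cc1ccccc1` stands highest of the two numbers in a functional assay on CCRF-CEM cells (Homo sapiens) for inhibition; a lower number here means that less compound is tolerated, a higher number that more compound is tolerated: compound 2 gives 108000 nM, while compound 1 `O=C1c2ccccc2N(Cc2ccccc2)S(=O)(=O)N1Cc1ccc(Cl)cc1` gives 27800 nM. Among the compounds with values here, the one step known, a 3.9-fold higher number from compound 1 to compound 2 (0.59 log units; beyond the scatter), is the single comparison that bears on compound 3 `O=C1c2ccccc2N(Cc2ccc(Cl)cc2)S(=O)(=O)N1Cc1ccccc1`, where the change is chloro in place of hydrogen on an aromatic carbon, on the benzyl attached to the sulfonamide nitrogen rather than the one beside the carbonyl. By analogy a modest lowering is expected, a 2.7-fold lower number from compound 2 to compound 3 (0.43 log units; beyond the scatter), though the ring differs. Compound 3 is therefore estimated at 40000 nM, within 15000 nM to 110000 nM.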

Compound 3, half-maximal cytotoxic concentration: 19700 nM
Compound 3: the middle estimate sits 2.0-fold (0.31 log units) above what was measured, within the range that was stated.
By their numbers in this assay, from the lowest: compounds 3 and 1 (each within the scatter of the next); then compound 2.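

In this assay, changing benzyl to 4-chlorobenzyl at the second benzyl of the shared core also lowers the number, a 5.5-fold lower number from compound 2 to compound 3 (0.74 log units; beyond the scatter), so the effect of chloro is not confined to one benzyl. The step is modest, as is the change at the first benzyl, read in reverse in a 3.9-fold higher number from compound 1 to compound 2 (0.59 log units; beyond the scatter). Nothing available explains the lowering at either benzyl. Still open, going by these compounds, are whether chloro on both benzyl groups together lowers the number further, and whether a methoxy group or an amine at the same place behaves like chloro.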